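One ring stereocentre inverted at the stability limit

The source may hold more compounds than are shown below. What is called first, only, known or untested is meant among the compounds shown, and "the series" means these compounds.

Compound 1 (`O=C(O)[C@H](CO)NC(=O)[C@H]1C[C@H](O)CN1`) and compound 2 (`O=C(O)[C@@H](CO)NC(=O)[C@H]1C[C@@H](O)CN1`) were both tested in an ADME assay on liver (Mus musculus, strain C57BL/6) for metabolic stability, read by HPLC, with a stated time of 12 h; a lower number here means that the compound disappears faster, a higher number that the compound lasts longer. Compound 1 gives > 12 h, which is a limit of the assay and not a number. Compound 2 gives > 12 h, which is likewise a limit, so this compound has no exact half-life to start from. Compound 3 (`O=C(O)[C@@H](CO)NC(=O)[C@H]1C[C@H](O)CN1`) departs from it through (the two compounds have the same atoms and bonds and differ only in configuration as drawn: 1 of 3 stereo elements differ; a stereocentre at a saturated ring carbon is drawn R in compound 2 and S in compound 3). Within the data shown here, the one measured step that bears on this is a step that the two limits leave unreadable from compound 1 to compound 2, which has no size to carry over because of the limit of > 12 h in this assay, at which 2 of the 2 values shown sit. That step rests on (the fact that compounds 1 and 2 differ only in the configuration as drawn), and both its ends remain at the limit. The expected change is a step that the limit leaves unreadable from compound 2 to compound 3, and no shift beyond the scatter is expected in either direction. For compound 3 the estimated half-life is 14 h, within an expected range of 10 h to 24 h, and this assay will probably report only a limit.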

Compound 3, half-life: > 12 h
Compound 3 gave a limit, no number; the forecaster's own chance of this, stated with the estimate: 85%; the middle value lies beyond the limit too.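

Among these compounds, no step among compounds 1, 2 and 3 can be read in this assay, where all three stand at a limit of the assay. The compounds shown leave open how long each lasts beyond that limit, and whether configuration at either differing stereocentre changes the half-life.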